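The compounds below may be only part of what the source reports. "The series", "measured", "known", "first", "only" and "open" are said of these compounds alone.

Compounds measured in an ADME assay on cells (Hepatocyte, Homo sapiens) for metabolic stability, read by LC-MS, with a stated time of 1 h, tested at 5 uM; on this read-out lower numbers stand for a less stable compound and higher numbers for a more stable compound:
Compound 1 `CC(=O)Nc1nc(C)c(-c2nc(CC(F)(F)F)no2)s1`: "not determined" (no result reported)
Compound 2 `CC(=O)Nc1nc(C)c(-c2nc(CC(C)(C)CO)no2)s1`: 9.3%

Going by the values given here, compound 2 carries the only number at 9.3%, and compound 1 has no result, so no ranking is possible. Still unmeasured is compound 3 `CC(=O)Nc1nc(C)c(-c2nc(CC(C)(C)C(C)O)no2)s1`, which differs from compound 2 in one place: methyl in place of hydrogen on a saturated chain carbon bound to an oxygen on a saturated carbon and a saturated chain carbon. Methyl replaces hydrogen on a saturated chain carbon bound to an oxygen on a saturated carbon and a saturated chain carbon, turning 2-(hydroxymethyl)-2-methylpropyl into 3-hydroxy-2,2-dimethylbutyl. Among the compounds with values here, no step between measured compounds is available to size this change, so the expectation rests on compound 2 alone, at 9.3%. A small rise in this assay is expected, probably not beyond the scatter. The expected change is a number 4.7 percentage points higher from compound 2 to compound 3 (within the scatter). For compound 3 the estimated value is 14%, with an expected range of 5% to 32%.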

Compound 3, percent of the compound remaining: 35.2%
Estimate against measurement, compound 3: 21.2 percentage points below, and the stated range ends below it.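

In this assay this position on the side chain proves responsive: methyl in place of hydrogen on a saturated chain carbon bound to an oxygen on a saturated carbon and a saturated chain carbon gives a number 25.9 percentage points higher from compound 2 to compound 3 (beyond the scatter) and so lies beyond the scatter. Going by these compounds alone, until now the series held a single number and no sized step, so this is the first sign that the read-out moves with a change at this carbon. The change is small, hydroxymethyl to 1-hydroxyethyl, with 1 carbon entering. Nothing at hand accounts for the step.

Open, on these data alone, is whether an ethyl or a longer chain at this carbon would extend the step or reverse it. Also open, as far as these compounds go, is how a methyl ether or a carboxylic acid in place of the hydroxyl would read.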